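Notes on the aryl change from compound 3 to compound 4

The source may hold more compounds than are shown below. What is called first, only, known or untested is meant among the compounds shown, and "the series" means these compounds.

Compound 1 `Cc1oc2c([C@H]3CCN(C)C[C@H]3O)c(O)cc(O)c2c(=O)c1C(O)c1cccc(Cl)c1`: 31%
Compound 2 `Cc1oc2c([C@H]3CCN(C)C[C@H]3O)c(O)cc(O)c2c(=O)c1C(O)c1c(Cl)cccc1Cl`: 0%
Compound 3 `Cc1oc2c([C@H]3CCN(C)C[C@H]3O)c(O)cc(O)c2c(=O)c1C(O)c1c(F)cccc1Cl`: 0%

In a functional assay on PC-3 cells (Homo sapiens) for inhibition, read by MTT assay, with a stated time of 48 h, tested at 10 uM (on this read-out lower numbers stand for less inhibition of growth and higher numbers for more inhibition of growth at the one concentration tested), compound 3 gives 0%, level with compound 2 and, together with it, the lowest of the three. Compound 4 `CCOc1ccc(Br)c(C(O)c2c(C)oc3c([C@H]4CCN(C)C[C@H]4O)c(O)cc(O)c3c2=O)c1` is unmeasured and brings 2-bromo-5-ethoxyphenyl in place of 2-chloro-6-fluorophenyl on a saturated chain carbon bound to an aromatic carbon and an oxygen on a saturated carbon. Two large steps, beyond the scatter, bear on this: a number 31 percentage points lower from compound 1 to compound 2 (beyond the scatter) and a number 31 percentage points lower from compound 1 to compound 3 (beyond the scatter). The exchange no change at the digits printed from compound 2 to compound 3 (within the scatter) lies within it. Compound 4 carries neither ring that gave the low values, so a rise part of the way towards compound 1 at 31% is expected, though with little support. The expected change in this assay is a number 15 percentage points higher from compound 3 to compound 4 (beyond the scatter). For compound 4 the estimated value is 15%, with an expected range of 0% to 40%.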

Compound 4, percent growth inhibition at one concentration: 0%
Compound 4: the middle estimate sits 15 percentage points above what was measured; measured number inside the range.
By their numbers in this assay, from the lowest: compounds 2, 3 and 4 (each within the scatter of the next); then compound 1.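

In this assay, the low read-out is not confined to the 2,6-dichlorophenyl and 2-chloro-6-fluorophenyl groups: the data show no change at the digits printed from compound 3 to compound 4 (within the scatter) and no change at the digits printed from compound 2 to compound 4 (within the scatter), set against a number 31 percentage points lower from compound 1 to compound 4 (beyond the scatter). Among the four aryl groups at this saturated chain carbon, only the 3-chlorophenyl group of compound 1 stands apart. No measurement on hand bears on the reason for this.

Still open, from the compounds shown here alone, is whether bromo or ethoxy alone would give the same read-out as 2-bromo-5-ethoxyphenyl. Also open, going by these compounds, is whether unsubstituted phenyl, or an amine on the ring, would keep the read-out of compound 1.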